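The source may hold more compounds than are shown below. What is called first, only, known or untested is meant among the compounds shown, and "the series" means these compounds.

Measured compounds:
Compound 1, `O=C(Nc1cccc(-n2cc(-c3ccncc3)c(-c3cc(O)cc(Cl)c3)n2)c1)Nc1ccc(Cl)c(C(F)(F)F)c1`, gives 100% in a functional assay on MOLT-4 cells (Homo sapiens) for inhibition, read by sulforhodamine B assay, with a stated time of 48 h, tested at 0.01 uM; a higher number here means a weaker effect of the compound at the concentration tested, a lower number a stronger effect.
Compound 2, `COc1cc(Cl)cc(-c2nn(-c3cccc(NC(=O)Nc4ccc(Cl)c(C(F)(F)F)c4)c3)cc2-c2ccncc2)c1`, gives 99% in this assay.
Compound 3, `COc1cc(Cl)cc(-c2nn(-c3cccc(NC(=O)Nc4cc(C(F)(F)F)cc(C(F)(F)F)c4)c3)cc2-c2ccncc2)c1`, gives 94% in this assay.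

On these numbers compound 2 stands second highest of three, within the scatter of compound 1 and of compound 3. Going by the values given here, the only single-point step known, a number 1 percentage points lower from compound 1 to compound 2 (within the scatter), lies within the scatter. Compound 4, `COc1cc(Cl)cc(-c2nn(-c3cccc(NC(=O)c4cccc(C(F)(F)F)c4)c3)cc2-c2ccncc2)c1`, differs from compound 2 by 3-(trifluoromethyl)phenyl in place of (4-chloro-3-(trifluoromethyl)phenyl)amino on a carbonyl carbon. Among the compounds with values here, no measured step touches the carbonyl carbon, so nothing measured bears directly on this change; compound 2 and compound 3 merely show that a different aryl group left the number within the scatter. Within the data shown here, with every number so far near full activity, the expected step of a number 1 percentage points lower from compound 2 to compound 4 (within the scatter) in this assay is none beyond the scatter. Compound 4 is therefore estimated at 98%, ranging from 85% to 105%.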

Compound 4, a percentage reported as activity, at one concentration (the size of the read-out at that concentration, not a potency): 91%
Compound 4: the middle estimate sits 7 percentage points above what was measured; measured number inside the range.
By their numbers in this assay, from the lowest: compounds 4, 3, 2 and 1 (each within the scatter of the next).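

Putting 3-(trifluoromethyl)phenyl in place of (4-chloro-3-(trifluoromethyl)phenyl)amino on the carbonyl carbon removes the amino nitrogen, its hydrogen-bond donor and the chlorine, and gives a number 8 percentage points lower from compound 2 to compound 4 (within the scatter) in this assay. At this single concentration, the two groups therefore cannot be told apart, so neither that nitrogen nor that chlorine is shown to matter for the read-out here. No supporting measurement is available to explain the step. Still open, as far as these compounds go, is how a smaller group on that carbonyl carbon, such as methyl, or a morpholine ring would behave. The compounds also leave open whether compound 2 and compound 4 would separate at other concentrations.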